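Swapping bromo for trifluoromethyl in a three-compound cytotoxicity series

The source may report more compounds than this note shows. Statements on the series, on what has been measured and on what is new or still open speak of the compounds shown alone.

Measured in an ADME assay on BHK-21 cells (Mesocricetus auratus) for cytotoxicity, read by MTT assay, with a stated time of 72 h; a higher number here means that more compound is tolerated, a lower number that less compound is tolerated:
compound 1 `FC(F)(F)c1ccc(-c2nn(-c3ccccc3)cc2CNc2ccc(Cl)cc2)cc1`: 31000 nM
compound 2 `Cc1ccc(NCc2cn(-c3ccccc3)nc2-c2ccc(C(F)(F)F)cc2)cc1`: 88000 nM
compound 3 `FC(F)(F)c1ccc(NCc2cn(-c3ccccc3)nc2-c2ccc(Br)cc2)cc1`: 20000 nM
Still to be measured: compound 4 `FC(F)(F)c1ccc(NCc2cn(-c3ccccc3)nc2-c2ccc(C(F)(F)F)cc2)cc1`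

In this assay compound 3 gives 20000 nM, within the scatter of compound 1 at 31000 nM. Compound 2, at 88000 nM, stands higher than compound 3, beyond the scatter.

Compound 4 differs from compound 3 by a single exchange, trifluoromethyl in place of bromo on an aromatic carbon. Among the compounds with values here, no measured step covers this exchange. The only one available, a 2.8-fold higher number from compound 1 to compound 2 (0.45 log units; beyond the scatter), is methyl in place of chloro on an aromatic carbon, so it bears only loosely here and gives a rough sense of how far one small exchange can move the number. Compound 1 already carries the 4-(trifluoromethyl)phenyl group and gives 31000 nM, which offers no reason to expect a large shift. The expected change is small and slightly upward, a 1.3-fold higher number from compound 3 to compound 4 (0.11 log units; within the scatter), and no step beyond the scatter is anticipated. For compound 4 the estimate is 26000 nM, with an expected range of 11000 nM to 60000 nM.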

Compound 4, half-maximal cytotoxic concentration: 27000 nM
Compound 4: the middle estimate sits 1.0-fold (0.02 log units) below what was measured; low and high end bracket the measured number.
By their numbers in this assay, from the lowest: compounds 3, 4 and 1 (each within the scatter of the next); then compound 2.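

In this assay the exchange of 4-bromophenyl to 4-(trifluoromethyl)phenyl gives a 1.4-fold higher number from compound 3 to compound 4 (0.13 log units; within the scatter) and so leaves the number within the scatter, which shows that this position tolerates the swap from bromo to trifluoromethyl without a measurable shift. Compound 4 also shows how the second variable position reads with trifluoromethyl: chloro and trifluoromethyl cannot be told apart there, with a 1.1-fold lower number from compound 1 to compound 4 (0.06 log units; within the scatter), whereas methyl stands apart, with a 3.3-fold lower number from compound 2 to compound 4 (0.51 log units; beyond the scatter) and only a modest difference. No measurement offered here explains either result.

On these data alone, whether methyl would also raise the number in place of bromo remains open, since its step is known only at the other position. So does the response at either position to a more different group, such as a carboxylic acid or an amine.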